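Benzyloxy Variants and Their Binding

The compounds below may be only part of what the source reports. "The series", "measured", "known", "first", "only" and "open" are said of these compounds alone.

Compound 1 `COc1cccc(OC)c1OCCNCCOc1ccccc1OCc1ccccc1C` gives 1.59 nM in an assay on CHO cells for displacement of a labelled ligand from Alpha-1A adrenergic receptor (Homo sapiens) (on this read-out lower numbers stand for stronger inhibition and higher numbers for weaker inhibition), the second highest of the three numbers measured. Compound 2 `COc1cccc(OC)c1OCCNCCOc1ccccc1OCc1cccc(C)c1` gives 0.398 nM, and compound 3 `COc1cccc(OC)c1OCCNCCOc1ccccc1OCc1ccc(C)cc1` gives 2 nM. Compound 4 `COc1ccc(COc2ccccc2OCCNCCOc2c(OC)cccc2OC)cc1` differs from compound 1 in one place: 4-methoxyphenyl in place of 2-methylphenyl on a saturated chain carbon bound to an oxygen on an aromatic ring. Among the measured steps, a 4.0-fold lower number from compound 1 to compound 2 (0.60 log units; beyond the scatter), whereas a 1.3-fold higher number from compound 1 to compound 3 (0.10 log units; within the scatter). For the measured compounds named here, the step to compound 4 resembles the latter, since the 4-methylphenyl of compound 3 and the 4-methoxyphenyl of compound 4 differ only in the group carried on the ring, and no measured pair shows what that exchange does. Compound 4 is therefore expected to stay within the scatter of compound 1, a 1.3-fold higher number from compound 1 to compound 4 (0.10 log units; within the scatter), at an estimated 2 nM (range 0.7 nM to 6 nM).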

Compound 4, inhibition constant: 2 nM
Compound 4: middle estimate and measured number agree at the digits printed, and the stated range covers the measured number.
By their numbers in this assay, from the lowest: compound 2; then compounds 1, 3 and 4 (each within the scatter of the next).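

In this assay, for the compounds shown here, the exchange of methyl for methoxy on an aromatic carbon, which no earlier pair covered, can now be read directly: no change at the digits printed from compound 3 to compound 4 (within the scatter). The 4-methoxyphenyl group also stays level with 2-methylphenyl, with a 1.3-fold higher number from compound 1 to compound 4 (0.10 log units; within the scatter), while the 3-methylphenyl of compound 2 remains apart, with a 5.0-fold higher number from compound 2 to compound 4 (0.70 log units; beyond the scatter). No available evidence bears on these steps.

As far as these compounds go, whether methoxy in place of methyl would likewise leave the number of compound 2 unchanged stays open, as it did for compound 3. Also open, from the compounds shown here alone, is what an amine or a carboxylic acid on that ring would give.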